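The source may report more compounds than this note shows. Statements on the series, on what has been measured and on what is new or still open speak of the compounds shown alone.

Of the compounds shown here, three sharing one core have been measured in a functional assay on KM12 cells (Homo sapiens) for inhibition; a lower number here means a stronger inhibitor of growth, a higher number a weaker inhibitor of growth. In this test compound 1 `COc1cc(/C=C/c2ccc(S(N)(=O)=O)cc2)cc(OC)c1` gives 20800 nM, compound 2 `NS(=O)(=O)c1ccc(/C=C/c2ccc(O)c(O)c2)cc1` gives 18200 nM and compound 3 `NS(=O)(=O)c1ccc(/C=C/c2ccc(F)cc2)cc1` gives 16300 nM. Compound 3 holds the lowest of the three numbers, but all three lie within the usual scatter of one another, so its place carries no real ranking. The account now follows one structural change. Compound 4 `NS(=O)(=O)c1ccc(/C=C/c2ccc(O)cc2)cc1` has hydroxy in place of fluoro on an aromatic carbon, para to a large group, as compound 3 does for its fluoro: hydroxy in place of fluoro on an aromatic carbon. Among the measured compounds shown here, no pair of measured compounds differs in only one place, so the data offer no direct precedent for this swap. The nearest hint is compound 2, which also bears hydroxy on that aromatic ring and gives 18200 nM. That value is not distinguishable from the others in this assay. No change beyond the scatter is therefore expected, and no firm direction can be called. The expected size of the move is a 1.0-fold higher number from compound 3 to compound 4 (0.02 log units; within the scatter). For compound 4 the estimated value is 17000 nM, with an expected range from 8000 nM to 35000 nM.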

Compound 4, concentration for 50% growth inhibition: 11100 nM
Beside the measured number, compound 4's estimate is 1.5-fold (0.19 log units) above it; low and high end bracket the measured number.
By their numbers in this assay, from the lowest: compounds 4, 3, 2 and 1 (each within the scatter of the next).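

In this assay, among the compounds shown here, hydroxy in place of fluoro on an aromatic carbon, para to a large group, gives a 1.5-fold lower number from compound 3 to compound 4 (0.17 log units; within the scatter), the first direct reading of this position: fluoro, which counts no hydrogen-bond donor or acceptor, gives way to hydroxy, which counts both, and the step stays within the scatter. The second step, hydrogen in place of hydroxy on an aromatic carbon, gives a 1.6-fold lower number from compound 2 to compound 4 (0.21 log units; within the scatter), also within the scatter, so neither single change on this ring separates its two compounds in this test. No measurement shown here offers an explanation for either step.

The compounds shown leave open whether any group on this aromatic carbon can move the number beyond the scatter, for instance an amine, a carboxylic acid, a methoxy or a longer chain such as propyl in place of the hydroxy of compound 4. They also leave open whether the flat reading at this position holds for the sulfonamide end of the shared core, where a carboxylic acid or a nitrile could stand in its place.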